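Lengthening a Chain on the Shared Core: Compound 4

A few compounds are considered here, and "the series" means these few. Any claim that something is new, unique, unknown or untested is made for them only; others in the source may bear on it.

Of the compounds shown here, three built on one shared core have been measured in a functional assay on HT-1080 cells (Homo sapiens), read by transwell migration, with a stated time of 24 h, tested at 0.1 uM; a lower number here means a stronger effect, a higher number a weaker effect of the compound at the concentration tested. Compound 1 `CC(=O)OCc1ccc2oc(=O)c(C(=O)Nc3cccc(Cl)c3)cc2c1` gives 79.6%. Compound 2 `CCC(=O)OCc1ccc2oc(=O)c(C(=O)Oc3cccc(Br)c3)cc2c1` gives 84.4%, and compound 3 `CCCC(=O)OCc1ccc2oc(=O)c(C(=O)Oc3cccc(Br)c3)cc2c1` gives 88.6%. Compound 3 holds the highest of the three numbers, but its gaps to compound 2 and to compound 1 both stay within the scatter, so no order among the three can be claimed.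

Compound 4 `CCCCCC(=O)OCc1ccc2oc(=O)c(C(=O)Oc3cccc(Br)c3)cc2c1` has not yet been measured. It differs from compound 3 in one place: ethyl in place of hydrogen on a saturated chain carbon, three bonds along the chain from a carbonyl carbon. Within the data shown here, only one measured step bears on a change of this kind, namely a number 4.2 percentage points higher from compound 2 to compound 3 (within the scatter), and it stayed within the scatter. Among the measured compounds shown here, because the sole comparable step is a number 4.2 percentage points higher from compound 2 to compound 3 (within the scatter), the expected step in this assay is a number 1.4 percentage points higher from compound 3 to compound 4 (within the scatter), small and with no direction that clearly goes beyond the scatter. Compound 4 is therefore estimated at 90%, with a range from 80% to 98%.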

Compound 4, a percentage reported as activity, at one concentration (the size of the read-out at that concentration, not a potency): 94.3%
Beside the measured number, compound 4's estimate is 4.3 percentage points below it; the range from low to high includes it.
By their numbers in this assay, from the lowest: compounds 1, 2, 3 and 4 (each within the scatter of the next, the first and the last beyond it).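

In this assay, adding ethyl in place of hydrogen, three bonds along the chain from a carbonyl carbon, gives a number 5.7 percentage points higher from compound 3 to compound 4 (within the scatter), and the wider comparison, with propyl in place of hydrogen two bonds along the chain, gives a number 9.9 percentage points higher from compound 2 to compound 4 (within the scatter). Even this larger change in chain length stays within the scatter, so the position accepts a longer chain with no clear difference in the read-out, and no trend with chain length can be claimed. No independent measurement here bears on what lies behind these numbers.

On these data alone, whether a still longer chain, or an amine or a carboxylic acid on this chain, would give a number beyond the scatter remains open. The compounds shown also leave open how these chains would read on compound 1, which differs from the others in more than one place.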